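The source may hold more compounds than are shown below. What is called first, only, known or untested is meant among the compounds shown, and "the series" means these compounds.

Measured compounds in a functional assay on IMR-32 cells with melanin-concentrating hormone receptor 1 (Homo sapiens) as the target, read by fluorescence; on this read-out lower numbers stand for stronger inhibition and higher numbers for weaker inhibition:
compound 1 `CC(CNCC1CCCC1)Oc1cccc2ccc(N)nc12` gives 100 nM
compound 2 `CC(CNC1CC1)Oc1cccc2ccc(N)nc12` gives 580 nM
compound 3 `COc1cccc(CNCC(C)Oc2cccc3ccc(N)nc23)c1` gives 600 nM

Compound 1 stands lowest of the three numbers in this assay; compound 2 and compound 3 both sit beyond the scatter from it. Compound 4 `CC(CNCc1ccsc1)Oc1cccc2ccc(N)nc12` is not yet measured. It differs from compound 1 in one place: thiophen-3-yl in place of cyclopentyl on a saturated chain carbon bound to an amine nitrogen.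

Among the measured compounds shown here, two measured steps bear on this. Changing the amine substituent gave a 5.8-fold higher number from compound 1 to compound 2 (0.76 log units; beyond the scatter), and exchanging cyclopentyl for a ring of the aromatic kind gave a 6.0-fold higher number from compound 1 to compound 3 (0.78 log units; beyond the scatter). Both moves away from cyclopentyl cost potency to a modest degree. A five-membered aromatic ring with 1 hetero atom is a smaller exchange than 3-methoxyphenyl, so a loss of similar or slightly smaller size is expected, in the direction of higher numbers. Compound 4 is therefore estimated at 300 nM in this assay, range 120 nM to 800 nM, meaning an expected step of a 3.0-fold higher number from compound 1 to compound 4 (0.48 log units; beyond the scatter).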

Compound 4, half-maximal inhibitory concentration: 150 nM
Beside the measured number, compound 4's estimate is 2.0-fold (0.30 log units) above it; the measured number falls inside the stated range.
By their numbers in this assay, from the lowest: compounds 1 and 4 (each within the scatter of the next); then compounds 2 and 3 (each within the scatter of the next).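

In this assay, thiophen-3-yl on a saturated chain carbon bound to an amine nitrogen stays within the scatter of cyclopentyl (a 1.5-fold higher number from compound 1 to compound 4 (0.18 log units; within the scatter)), so an aromatic ring at this place does not in itself go with a loss. Compound 3 carries an aromatic ring too and stands apart (a 4.0-fold lower number from compound 3 to compound 4 (0.60 log units; beyond the scatter)), as does the cyclopropyl amine (a 3.9-fold lower number from compound 2 to compound 4 (0.59 log units; beyond the scatter)). Nothing at hand accounts for these differences. Unsubstituted phenyl, thiophen-2-yl and furan-3-yl remain open at this place, so the separate contributions of ring size, hetero atom and methoxy substituent stay unresolved.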